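The source may hold more compounds than are shown below. What is called first, only, known or untested is meant among the compounds shown, and "the series" means these compounds.

Measured compounds:
Compound 1 `COc1ccc(-c2c(C)nc3c(N4CC[C@@H](NC(C)=O)C4)cc(C)nn23)cc1F` gives > 95% in an ADME assay on microsomes from liver (Mus musculus) for metabolic stability, read by LC-MS, with NADPH named in the record, with a stated time of 60 min, tested at 1 uM, in the absence of a further agent (a higher number here means that more of the compound is left, a lower number that less of the compound is left), which is a limit of the assay rather than a number.
Compound 2 `CC(=O)N[C@@H]1CCN(c2cc(C)nn3c(-c4ccco4)c(C)nc23)C1` gives > 95% in this assay, again a limit.
Compound 3 `COc1ccc(-c2c(C)nc3c(N4CC[C@@H](NC(=O)OCc5ccccc5)C4)cc(C)nn23)cc1OC` gives > 95% in this assay, again a limit.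

Compound 3 therefore stands at the upper limit of what this assay reports, and it shares that position with both other measured compounds, since all three values sit at the limit of > 95% in this assay, at which 3 of the 3 values shown sit. Among the measured compounds shown here, only one pair of measured compounds differs in a single place, and that step, a step that the two limits leave unreadable from compound 1 to compound 2, cannot be sized because both ends are limits; it concerns an aromatic carbon, not the saturated ring carbon changed here.

Compound 4 `COc1ccc(-c2c(C)nc3c(N4CC[C@@H](O)C4)cc(C)nn23)cc1OC` differs from compound 3 in one place: hydroxy in place of (benzyloxycarbonyl)amino on a saturated ring carbon. For the measured compounds named here, no measured step bears on this change, so the expectation rests only on every measured value sitting at the limit. Compound 4 is therefore expected to remain largely intact, with an estimated 90%. The step from compound 3 to compound 4 is expected to be a number at least 5 percentage points lower from compound 3 to compound 4 (that floor lies within the scatter), which may amount to nothing beyond the scatter.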

Compound 4, percent of the compound remaining: > 95%
Compound 4 was reported as a limit (the forecaster's own chance of this, stated with the estimate: 55%); at least 5 percentage points between middle value and limit.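

Compound 3 and compound 4 both stand at a limit in this assay and so the step between them cannot be read: the limit of > 95% in this assay, at which 4 of the 4 values shown sit.

The compounds shown leave open how much any of these group changes alters the percent of compound remaining, as no value falls short of that limit.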